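The source may hold more compounds than are shown below. What is called first, only, known or untested is meant among the compounds shown, and "the series" means these compounds.

Measured compounds in the series:

compound 1, `CCN(CC)C(=O)COc1ccc2cc(C(O)(C(F)(F)F)C(F)(F)F)c(O)cc2c1` — > 20000 nM
compound 2, `Cc1ccc(S(=O)(=O)NNC(=O)COc2ccc3cc(C(O)(C(F)(F)F)C(F)(F)F)c(O)cc3c2)cc1` — 16100 nM

Both were tested in an assay on isolated protein for inhibition of receptor-type tyrosine-protein phosphatase C (Homo sapiens), read by spectrophotometry; on this read-out lower numbers stand for stronger inhibition and higher numbers for weaker inhibition. For compound 1 the result is a limit of the assay, not a number. Among the measured compounds shown here, compound 2 gives 16100 nM, which is the only number so far; the other result sits at the limit of > 20000 nM in this assay, at which 1 of the 2 values shown sits. The step of an at least 1.2-fold lower number from compound 1 to compound 2 (0.09 log units; that floor lies within the scatter) is therefore known only as a floor, and that floor lies within the scatter.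

Compound 3, `O=C(COc1ccc2cc(C(O)(C(F)(F)F)C(F)(F)F)c(O)cc2c1)Nc1ccc(-c2ccccc2)cc1`, is the next analogue. Its change from compound 2 is 4-phenylphenyl in place of ((4-methylphenyl)sulfonyl)amino on an amide-type nitrogen. For the measured compounds named here, the only measured step that touches this position is the one from compound 1 to compound 2, and it sets no clear direction for the amide-type nitrogen substituent. For compound 3 no step beyond the scatter is expected in this assay, and the estimated step of a 1.3-fold lower number from compound 2 to compound 3 (0.13 log units; within the scatter) is therefore small. Compound 3 is estimated at 12000 nM, with a range from 3000 nM to 40000 nM, and a fair chance that only a limit is reported.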

Compound 3, half-maximal inhibitory concentration: 3400 nM
Beside the measured number, compound 3's estimate is 3.5-fold (0.55 log units) above it; measured number inside the range.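

In this assay, among the compounds shown here, the series now shows a 4.7-fold lower number from compound 2 to compound 3 (0.68 log units; beyond the scatter) and this is the first step at the amide-type nitrogen that can be read as lying beyond the scatter, so the substituent at this position does move the number. The change also shows that the ((4-methylphenyl)sulfonyl)amino group, with its hydrogen-bond donor and acceptors, is not required to reach the number of compound 3, as 4-phenylphenyl carries no hydrogen-bond donors or acceptors and two six-membered aromatic rings of carbon only. Compound 1 remains a limit of the assay, so its step to compound 2 still cannot be read as a size, and the diethylamino group cannot be placed in the order: the limit of > 20000 nM in this assay, at which 1 of the 3 values shown sits.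

With the ring count, the sulfonyl group and the hydrogen-bond donors and acceptors all changing in one step, the compounds shown do not separate their contributions, and a plain phenyl on the same nitrogen, or a carboxylic acid or an amine added to the 4-phenylphenyl group, would be needed to take them apart. Nothing shown gives a reason for the size of this step.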